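The compounds below may be only part of what the source reports. "The series", "measured", "known", "first", "only" and "open" are said of these compounds alone.

In a functional assay on A549 cells (Homo sapiens) for inhibition, read by MTT assay, with a stated time of 48 h (a lower number here means a stronger inhibitor, a higher number a weaker inhibitor), compound 3 `COc1ccc2c(=O)c(/C=C/C(=O)Nc3ccc(C)cc3)coc2c1` gives 17500 nM, the lowest of the two numbers shown, and compound 1 `COc1ccc2c(=O)c(/C=C/C(=O)Nc3ccccc3Cl)coc2c1` gives 29900 nM; the step between them, a 1.7-fold lower number from compound 1 to compound 3 (0.23 log units; within the scatter), lies within the scatter. Compound 2 `COc1ccc2c(=O)c(/C=C/C(=O)NCc3ccccc3F)coc2c1` in this assay gives > 100000 nM, which is a limit, (the limit of > 100000 nM in this assay, at which 1 of the 3 values shown sits). The steps of an at least 3.3-fold higher number from compound 1 to compound 2 (0.52 log units; beyond the scatter) and an at least 5.7-fold lower number from compound 2 to compound 3 (0.75 log units; beyond the scatter) each exchange the whole group on the amide-type nitrogen. Compound 4 `CCOc1ccc(NC(=O)/C=C/c2coc3cc(OC)ccc3c2=O)cc1` differs from compound 3 by ethoxy in place of methyl on an aromatic carbon, sitting para to a large group. Within the data shown here, none of the measured steps varies a substituent on that ring, so they offer no direct guide, and compound 4 is expected to show a 1.2-fold lower number from compound 3 to compound 4 (0.07 log units; within the scatter), no step beyond the scatter. The estimate for compound 4 in this assay is 15000 nM, between 6000 nM and 40000 nM.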

Compound 4, half-maximal inhibitory concentration: > 100000 nM
Compound 4 ended at the assay's limit; the forecaster's own chance of this, stated with the estimate: 5%; middle value at least 6.6-fold (0.82 log units) from the limit.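

In this assay, among these compounds, the step of an at least 5.7-fold higher number from compound 3 to compound 4 (0.75 log units; beyond the scatter) shows that this position is not indifferent to the group it carries: ethoxy in place of methyl, para to a large group, moves the number beyond the scatter, which no earlier step on this ring could show. The step of an at least 3.3-fold higher number from compound 1 to compound 4 (0.52 log units; beyond the scatter) is likewise beyond the scatter. Compound 2 and compound 4 both stand at a limit, so the step between them cannot be read: the limit of > 100000 nM in this assay, at which 2 of the 4 values shown sit.

Going by these compounds, whether the oxygen or the longer chain goes with this change stays open. Methoxy or ethyl at this place would separate the two.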